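Benzylidene tetralone series: para-dimethylamino analogue pending

The source may report more compounds than this note shows. Statements on the series, on what has been measured and on what is new or still open speak of the compounds shown alone.

Measured so far in a functional assay on L1210 cells (Mus musculus) for inhibition; a higher number here means a weaker inhibitor, a lower number a stronger inhibitor:
compound 1 `O=C1/C(=C/c2ccccc2)CCc2ccccc21` gives 121000 nM;
compound 2 `O=C1/C(=C/c2cccc(F)c2)CCc2ccccc21` gives 61200 nM;
compound 3 `Cc1cccc(/C=C2\CCc3ccccc3C2=O)c1` gives 73200 nM.

Compound 1 carries the highest of the three numbers, but its distance to compound 3 and to compound 2 is within the scatter, so no order among the three is established. The next compound, compound 4 `CN(C)c1ccc(/C=C2\CCc3ccccc3C2=O)cc1`, differs from compound 1 by dimethylamino in place of hydrogen on an aromatic carbon. The two steps that bear on it, a 2.0-fold lower number from compound 1 to compound 2 (0.30 log units; within the scatter) and a 1.7-fold lower number from compound 1 to compound 3 (0.22 log units; within the scatter), both stay within the scatter, so single substitution on that ring has so far left this assay essentially unchanged. For the measured compounds named here, no step for a dimethylamino group is available. Compound 4 is therefore expected near compound 1, with a step of a 1.5-fold lower number from compound 1 to compound 4 (0.18 log units; within the scatter). The estimate for compound 4 is 80000 nM, with a range of 25000 nM to 250000 nM.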

Compound 4, half-maximal inhibitory concentration: 17500 nM
Beside the measured number, compound 4's estimate is 4.6-fold (0.66 log units) above it, outside the stated range (below it).
By their numbers in this assay, from the lowest: compound 4; then compounds 2, 3 and 1 (each within the scatter of the next).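

In this assay, for the compounds shown here, a 6.9-fold lower number from compound 1 to compound 4 (0.84 log units; beyond the scatter) is the only step that lies beyond the scatter, so a substituent on the shared core can shift this number measurably. The fluoro and methyl steps from compound 1 stayed within the scatter, so the dimethylamino change, on an aromatic carbon para to a large group, stands alone. No evidence on the cause of this step is available.

Open, going by these compounds, is whether the step depends on dimethylamino itself or would also appear with another group on the same carbon. A primary amine, a methoxy group or a diethylamino group there would test this.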